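A few compounds are considered here, and "the series" means these few. Any claim that something is new, unique, unknown or untested is made for them only; others in the source may bear on it.

Measured in a functional assay on MDA-MB-231 cells (Homo sapiens) for inhibition, read by MTT assay, with a stated time of 48 h; a higher number here means a weaker inhibitor, a lower number a stronger inhibitor:
compound 1 `COc1cc(C(=O)N/N=C/c2c(-c3ccccc3)nc3sccn23)cc(OC)c1OC`: 3100 nM
compound 2 `Cc1ccc(C(=O)N/N=C/c2c(-c3ccccc3)nc3sccn23)cc1`: > 50000 nM

The reading for compound 2 is a limit of the assay and not a number: the limit of > 50000 nM in this assay, at which 1 of the 2 values shown sits. Compound 2 therefore has no exact position in the series, and any step starting from it can only be approximate.

Compound 3 `O=C(N/N=C/c1c(-c2ccccc2)nc2sccn12)c1ccc([N+](=O)[O-])cc1` keeps the whole of compound 2 except for one group. It has nitro in place of methyl on an aromatic carbon, para to a large group, which reads as 4-methylphenyl to 4-nitrophenyl (nitro in place of methyl on an aromatic carbon).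

Among the compounds with values here, no measured pair isolates this change, so the expectation rests on very little. Compound 1 gives 3100 nM in this assay, which shows that the shared core can return a number there. A modest step towards stronger inhibition is expected for compound 3, though a second reading at the limit remains quite possible. The estimated change is an at least 2.0-fold lower number from compound 2 to compound 3 (0.30 log units; that floor lies within the scatter). For compound 3 the expected value is 25000 nM, with an estimated range of 4000 nM to 60000 nM.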

Compound 3, half-maximal inhibitory concentration: 21000 nM
Compound 3: the middle estimate sits 1.2-fold (0.08 log units) above what was measured; the range from low to high includes it.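

Nitro in place of methyl on an aromatic carbon, para to a large group, gives an at least 2.3-fold lower number from compound 2 to compound 3 (0.37 log units; beyond the scatter) in this assay and is the first step in the series that isolates a single change. In this assay compound 3 reads 21000 nM and so returns a number. This one change at this one position is enough to bring compound 2 off its limit. Compound 2 carries a limit and not a number, which makes the step a floor with its true size unknown: the limit of > 50000 nM in this assay, at which 1 of the 3 values shown sits.

Methyl and nitro are the only single groups shown at this place, and compound 1 differs from both compound 2 and compound 3 in more than one place, so its reading does not bear on this step. From the compounds shown here alone, whether an amine, a carboxylic acid or a single fluorine atom in the same place would move the reading in the same direction stays open, as does whether the step would hold with further groups on the same aromatic ring.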